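Hydroxy for Bromo on a Bis-benzylidene Cyclohexanone

The source may hold more compounds than are shown below. What is called first, only, known or untested is meant among the compounds shown, and "the series" means these compounds.

Measured compounds:
compound 1, `COc1ccc(/C=C2\CCC/C(=C\c3ccccc3Br)C2=O)cc1OC`, > 20000 nM
compound 2, `COc1ccc(/C=C2\CCC/C(=C\c3cccc(Br)c3)C2=O)cc1OC`, 12800 nM

Compound 1 reaches only the limit of a functional assay on A549 cells (Homo sapiens) for cytotoxicity, read by MTT assay, with a stated time of 72 h (on this read-out higher numbers stand for weaker inhibition and lower numbers for stronger inhibition), where (the limit of > 20000 nM in this assay, at which 1 of the 2 values shown sits). For the measured compounds named here, compound 2 is the sole compound with a number in this assay, giving 12800 nM. Going by the values given here, the one measured step, an at least 1.5-fold lower number from compound 1 to compound 2 (0.19 log units; that floor lies within the scatter), moves the bromo around the ring and does not touch the change now in question.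

Compound 3, `COc1ccc(/C=C2\CCC/C(=C\c3cccc(O)c3)C2=O)cc1OC`, differs from compound 2 by hydroxy in place of bromo on an aromatic carbon. Among the compounds with values here, no measured step bears on exchanging a halogen for a hydroxy at this place, so the expected shift has no direct support. The estimate for compound 3 therefore stays close to compound 2, with an expected step of a 1.3-fold lower number from compound 2 to compound 3 (0.11 log units; within the scatter) that does not exceed the scatter. Compound 3 is expected to give about 10000 nM, within 3000 nM to 30000 nM.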

Compound 3, half-maximal inhibitory concentration: 4300 nM
For compound 3 the middle estimate is 2.3-fold (0.37 log units) above the measured one, and the stated range covers the measured number.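

In this assay, the place that holds the bromo in compound 2 responds to a change of group, which the move of the bromo around the ring could not show: hydroxy in place of bromo gives a 3.0-fold lower number from compound 2 to compound 3 (0.47 log units; beyond the scatter). Set against the other bromo compound, the 3-hydroxyphenyl group gives an at least 4.6-fold lower number from compound 1 to compound 3 (0.66 log units; beyond the scatter). That step is only a floor, since compound 1 gives a limit of the assay and not a number: the limit of > 20000 nM in this assay, at which 1 of the 3 values shown sits.

The compounds shown leave open whether this shift belongs to hydroxy alone or would also come with a methoxy, an amine or a carboxylic acid on the same aromatic carbon. They also leave open how a hydroxy would behave where the bromo of compound 1 sits.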